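The source may report more compounds than this note shows. Statements on the series, on what has been measured and on what is new or still open speak of the compounds shown alone.

The series begins with compound 1 `Cc1cccc(-c2c(N)n[nH]c2C)c1`, compound 2 `Cc1[nH]nc(N)c1-c1cc(C(F)(F)F)cc(C(F)(F)F)c1` and compound 3 `CCCC(=O)n1nc(C)c(-c2ccc(Cl)c(Cl)c2)c1N`, three compounds that share a core and differ in their substituents. In an assay on Sf9 cells for inhibition of inhibitor of nuclear factor kappa-B kinase subunit epsilon (Homo sapiens), read by ADP-Glo, with a stated time of 60 min (on this read-out lower numbers stand for stronger inhibition and higher numbers for weaker inhibition), compound 1 returns only a limit of the assay, > 100000 nM, and not a number. Compound 2 likewise gives only a limit in this assay, > 100000 nM. Compound 3 also reaches no number in this assay and shows a limit, > 100000 nM. Compound 3 therefore stands where every compound here stands, at the limit of > 100000 nM in this assay, at which 3 of the 3 values shown sit; no ordering among the three can be read from these values, and none is the weakest or strongest.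

The next compound, compound 4 `CCNC(=O)n1nc(C)c(-c2ccc(Cl)c(Cl)c2)c1N`, follows from compound 3 by a single change: ethylamino in place of propyl on a carbonyl carbon. No measured pair among these compounds shows a step of this kind, so nothing here tells what such a change does in this assay. With all three values sitting at the limit, the step from compound 3 to compound 4 is expected to be none beyond the usual scatter, and compound 4 is expected to give a limit again rather than a number. The expected step is a number no higher from compound 3 to compound 4 (the limit leaves the size open). Compound 4 is thus estimated at 100000 nM in this assay, within a range from 30000 nM to 300000 nM.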

Compound 4, half-maximal inhibitory concentration: > 100000 nM
Compound 4: a limit, no number; the forecaster's own chance of this, stated with the estimate: 85%; the middle value sits exactly at the limit.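

Compound 3 and compound 4 both give only a limit in this assay, so no step between them can be read: the limit of > 100000 nM in this assay, at which 4 of the 4 values shown sit.

The compounds shown leave open which substituents on the shared core, if any, would give a number rather than a limit in this assay.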